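The source may report more compounds than this note shows. Statements on the series, on what has been measured and on what is new or still open speak of the compounds shown alone.

Working notes on the series. In a functional assay on A2780 cells (Homo sapiens) for inhibition, read by sulforhodamine B assay (a lower number here means a stronger inhibitor of growth, a higher number a weaker inhibitor of growth), compound 1 (`COc1ccc(-c2ccc(-c3ccc(-c4nc5cc(C)ccc5[nH]4)cc3)cc2)cc1OC`) gives 2130 nM and compound 2 (`COc1ccc(-c2ccc(-c3ccc(-c4nc5c(O)cccc5[nH]4)cc3)cc2)cc1OC`) gives 2710 nM, so compound 1 stands level with its only measured comparator, given a 1.3-fold higher number from compound 1 to compound 2 (0.10 log units; within the scatter). Compound 3 (`Cc1ccc2[nH]c(-c3ccc(-c4ccc(-c5ccc(O)cc5)cc4)cc3)nc2c1`) differs from compound 1 in one place: 4-hydroxyphenyl in place of 3,4-dimethoxyphenyl on an aromatic carbon. That measured step concerns a different group and says nothing direct about this exchange, so no step beyond the scatter is expected in this assay, and no direction can be given. The estimate is a 1.1-fold lower number from compound 1 to compound 3 (0.03 log units; within the scatter). Compound 3 is expected at 2000 nM, with an estimated range of 500 nM to 7000 nM.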

Compound 3, concentration for 50% growth inhibition: 31200 nM
Compound 3: middle estimate off by 16-fold (1.19 log units), on the low side; the measured number lies above the stated range.
By their numbers in this assay, from the lowest: compounds 1 and 2 (each within the scatter of the next); then compound 3.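

This place, on an aromatic carbon para to a large group, is sensitive to the aryl substituents in this assay: 4-hydroxyphenyl in place of 3,4-dimethoxyphenyl gives a 15-fold higher number from compound 1 to compound 3 (1.17 log units; beyond the scatter). Among the compounds shown here, the exchange at the other measured place gave only a 1.3-fold higher number from compound 1 to compound 2 (0.10 log units; within the scatter), so this is the first step beyond the scatter. No measurement shown bears on the cause of this step.

Open, on these data alone, is whether the step follows the entering hydroxyl or the departing methoxy groups. A 4-methoxyphenyl or a plain phenyl at this place would separate the two.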